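A pyrrolidinyl analogue of compound 1: expected cytotoxicity

The compounds below may be only part of what the source reports. "The series", "measured", "known", "first", "only" and "open" are said of these compounds alone.

Measured compounds:
Compound 1, `O=C(/C=C/c1ccc([N+](=O)[O-])o1)c1ccc(I)cc1`: 49500 nM
Compound 2, `O=C(/C=C/c1ccco1)c1ccc(N2CCCCC2)cc1`: > 50000 nM

In an ADME assay on THP-1 cells (Homo sapiens) for cytotoxicity, read by resazurin assay, with a stated time of 72 h (on this read-out higher numbers stand for lower toxicity in this test and lower numbers for higher toxicity in this test), compound 1 gives 49500 nM, the only numeric result among the two shown. For compound 2 the result is a limit of the assay rather than a number: the limit of > 50000 nM in this assay, at which 1 of the 2 values shown sits. The unmeasured compound 3, `O=C(/C=C/c1ccc([N+](=O)[O-])o1)c1ccc(N2CCCC2)cc1`, differs from compound 1 by pyrrolidin-1-yl in place of iodo on an aromatic carbon. Going by the values given here, compound 2 also carries a saturated nitrogen ring on its aromatic carbon ring, yet no step between it and compound 1 can be read, since the two differ in more than one place. Because compound 1 gives 49500 nM close to the upper edge of what this assay reports, the step of a 1.0-fold higher number from compound 1 to compound 3 (0.00 log units; within the scatter) is expected to stay within the scatter. Compound 3 is therefore estimated at 50000 nM, with a range from 20000 nM to 120000 nM.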

Compound 3, half-maximal cytotoxic concentration: > 50000 nM
Compound 3: a limit, no number (the forecaster's own chance of this, stated with the estimate: 50%); the middle value sits exactly at the limit.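

At this position, on an aromatic carbon para to a large group, pyrrolidin-1-yl in place of iodo in this assay gives a number no lower from compound 1 to compound 3 (the limit leaves the size open). Going by these compounds alone, this is the first step that can be read in the set, and it shows that a saturated nitrogen ring can stand at this place on the core of compound 1 without the number falling. How far the number rises cannot be told, since the result for compound 3 is a limit and not a number: the limit of > 50000 nM in this assay, at which 2 of the 3 values shown sit.

The compounds shown leave open whether a carboxylic acid or a primary amine at this position would bring the number down from this limit. They also leave open whether a longer chain ending in an amine would keep it there.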